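Methylsulfanyl Added to Compound 3: An Expected Outcome

The compounds below may be only part of what the source reports. "The series", "measured", "known", "first", "only" and "open" are said of these compounds alone.

In an assay on a protein complex for inhibition of ubiquitin carboxyl-terminal hydrolase 1/WD repeat-containing protein 48 (Homo sapiens), read by fluorescence (on this read-out higher numbers stand for weaker inhibition and lower numbers for stronger inhibition), compound 3 `CC(C)c1ccccc1-c1nccc(NCc2ccc(-c3cccnc3)cc2)n1` gives 150 nM, the lowest of the three numbers shown. Compound 1 `FC(F)(F)c1ccccc1-c1nc(NCc2ccccc2)c2ccccc2n1` gives 3100 nM in this assay, and compound 2 `FC(F)(F)c1ccc(CNc2nc(-c3ccccc3C(F)(F)F)nc3ccccc23)cc1` gives 8900 nM. Compound 4 `CSc1cnc(-c2ccccc2C(C)C)nc1NCc1ccc(-c2cccnc2)cc1` differs from compound 3 by methylsulfanyl in place of hydrogen on an aromatic carbon. Within the data shown here, the one measured step that adds a single group to an aromatic carbon is a 2.9-fold higher number from compound 1 to compound 2 (0.46 log units; beyond the scatter), which placed a trifluoromethyl on a different ring than the shared core, so it is only a loose guide. Among the measured compounds shown here, with no closer precedent, the change is expected to move the number little, most likely within the scatter, with a slight lean toward a higher number in this assay. Compound 4 is therefore estimated at 220 nM, within a range from 70 nM to 700 nM, an expected step of a 1.5-fold higher number from compound 3 to compound 4 (0.17 log units; within the scatter).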

Compound 4, half-maximal inhibitory concentration: 110 nM
The estimate for compound 4 lay 2.0-fold (0.30 log units) above the measured number, within the range that was stated.
By their numbers in this assay, from the lowest: compounds 4 and 3 (each within the scatter of the next); then compound 1; then compound 2.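

In this assay, a 1.4-fold lower number from compound 3 to compound 4 (0.13 log units; within the scatter) shows that this aromatic carbon of the six-membered ring with 2 nitrogen, para to a 2-isopropylphenyl group, can carry methylsulfanyl with no change beyond the scatter. The earlier step placed trifluoromethyl elsewhere and could not speak for this position, where the first substitution now leaves the number level with that of compound 3.

From the compounds shown here alone, whether an amine, a carboxylic acid or a longer chain on this carbon would also hold the number remains open. The data shown offer no explanation for this result.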